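Replacing Fluoro with Hydroxy on a Potent Compound

The source may report more compounds than this note shows. Statements on the series, on what has been measured and on what is new or still open speak of the compounds shown alone.

So far, two compounds with the same core have been measured. In a functional assay on COLO 205 cells (Homo sapiens) for antiproliferative activity, with a stated time of 72 h (a higher number here means a weaker inhibitor, a lower number a stronger inhibitor), compound 1 `C=C1C=CC(=O)[C@@H]2[C@H](Cc3ccc(OCOC)c(F)c3)CC[C@H]12` gives 75.7 nM, while compound 2 `C=C1C=CC(=O)[C@@H]2[C@H](Cc3ccc(OC)c(F)c3)CC[C@H]12` gives 2.45 nM, the lower of the two numbers and therefore the stronger result. Compound 3 `C=C1C=CC(=O)[C@@H]2[C@H](Cc3ccc(OC)c(O)c3)CC[C@H]12` differs from compound 2 at one place: hydroxy in place of fluoro on an aromatic carbon. This is hydroxy in place of fluoro on an aromatic carbon, ortho to a methoxy group.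

Among the compounds with values here, only one measured step is available for comparison. It is a 31-fold lower number from compound 1 to compound 2 (1.49 log units; beyond the scatter), with hydrogen in place of methoxy on a saturated chain carbon bound to an oxygen on an aromatic ring. That large step shows that a small edit can move the number a long way, but it involves a different group. Within the data shown here, no measured pair exchanges fluoro for anything, so the direction remains a cautious guess. Starting from the low number of compound 2, a modest loss is more likely than a large one. The expected step is a 2.4-fold higher number from compound 2 to compound 3 (0.39 log units; beyond the scatter), and the uncertainty is wide. In this assay the estimated value for compound 3 is 6 nM, with an expected range from 1.2 nM to 30 nM.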

Compound 3, half-maximal inhibitory concentration: 244 nM
Compound 3: the middle estimate sits 41-fold (1.61 log units) below what was measured; the whole stated range lies below it.
By their numbers in this assay, from the lowest: compound 2; then compound 1; then compound 3.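

In this assay the step of a 100-fold higher number from compound 2 to compound 3 (2.00 log units; beyond the scatter) shows that this aromatic position, ortho to a methoxy group, is highly sensitive: exchanging one heavy atom for another turns the more potent of the first two compounds into a much weaker one. Within the data shown here, the only earlier step of a 31-fold lower number from compound 1 to compound 2 (1.49 log units; beyond the scatter) involved a different place on the molecule, so this is the first sign that the group at the fluoro position also has a large effect on the number, and here the change is in the direction of weaker activity. Nothing available gives a measured reason for a loss of this size.

Among the compounds shown, fluoro and hydroxy are the only groups compared at this position, so it remains open whether the loss is specific to hydroxy or would follow from replacing fluoro with other groups. Plain hydrogen, chloro, an amine or a second methoxy group at this position would help to separate those two possibilities.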